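The source may hold more compounds than are shown below. What is called first, only, known or untested is meant among the compounds shown, and "the series" means these compounds.

Measured in a functional assay on A-375 cells (Homo sapiens) for antiproliferative activity, read by CCK-8 assay, with a stated time of 72 h, tested at 2 uM; on this read-out lower numbers stand for a weaker effect and higher numbers for a stronger effect at the one concentration tested:
compound 1 `Nc1ccccc1NC(=O)c1ccc(CSC(=S)N2CCN(C3CCCCC3)CC2)cc1`, 31.7%
compound 2 `CCN(Cc1ccncc1)C(=S)SCc1ccc(C(=O)Nc2ccccc2N)cc1`, 67.2%
compound 3 `Nc1ccccc1NC(=O)c1ccc(CSC(=S)N2CCc3ccc([N+](=O)[O-])cc32)cc1`, 22.1%

Compound 2 stands highest of the three numbers in this assay; compound 1 lies beyond the scatter below it, and compound 3 lies further below still. Compound 4 `Nc1ccccc1NC(=O)c1ccc(CSC(=S)N2CCCc3ccccc32)cc1` is not yet measured. It differs from compound 2 by 1,2,3,4-tetrahydroquinolin-1-yl in place of ethyl((pyridin-4-yl)methyl)amino on a thiocarbonyl carbon. Among the measured compounds shown here, no step between measured compounds shares this change, so its size must be judged from analogy: compounds 1 and 3, which like compound 4 carry a ring nitrogen on the thiocarbonyl carbon, both sit well below compound 2. A downward step beyond the scatter is therefore expected. Compound 4 is expected to give 30% (15% to 50%). The expected step is a number 37.2 percentage points lower from compound 2 to compound 4 (beyond the scatter).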

Compound 4, a percentage reported as inhibition, at one concentration (the size of the read-out at that concentration, not a potency): 26.5%
Beside the measured number, compound 4's estimate is 3.5 percentage points above it; measured number inside the range.
By their numbers in this assay, from the lowest: compounds 3, 4 and 1 (each within the scatter of the next); then compound 2.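

Replacing ethyl((pyridin-4-yl)methyl)amino with 1,2,3,4-tetrahydroquinolin-1-yl on a thiocarbonyl carbon gives a number 40.7 percentage points lower from compound 2 to compound 4 (beyond the scatter) in this assay, so this position is sensitive to the change even though both groups hold 10 heavy atoms. Compounds 3, 4 and 1 fall each within the scatter of the next, and all sit apart from compound 2. No supporting data bear on the origin of this step. On these data alone, whether the pyridine ring, the ethyl group or the open-chain amine matters most remains open. A benzyl group in place of the pyridin-4-ylmethyl group would help separate these parts.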